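The source may report more compounds than this note shows. Statements on the series, on what has been measured and on what is new or still open speak of the compounds shown alone.

Compound 1, `CC(=O)N1c2ccccc2CCC1C(=O)Nc1cc(C(F)(F)F)cc(C(F)(F)F)c1`, carries an acetyl group on the ring nitrogen of its shared core. In a functional assay on ACHN cells (Homo sapiens) for cytotoxicity, read by sulforhodamine B assay, with a stated time of 72 h (on this read-out lower numbers stand for stronger inhibition of growth and higher numbers for weaker inhibition of growth), compound 1 reaches only the limit of the measurement, > 70000 nM, and no number. Compound 2, `CCCC(=O)N1c2ccccc2CCC1C(=O)Nc1ccccc1C(F)(F)F`, bears a butanoyl group instead. In this assay compound 2 likewise stops at the limit, > 70000 nM. Compound 3, `O=C(Nc1ccccc1C(F)(F)F)C1CCc2ccccc2N1C(=O)c1ccccc1`, has a benzoyl group on that nitrogen, and in this assay compound 3 gives 8090 nM. For the measured compounds named here, the single measured step, an at least 8.6-fold lower number from compound 2 to compound 3 (0.93 log units; beyond the scatter), is the only change that moves a value off (the limit of > 70000 nM in this assay, at which 2 of the 3 values shown sit).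

Compound 4, `CCC(=O)N1c2ccccc2CCC1C(=O)Nc1cc(C(F)(F)F)cc(C(F)(F)F)c1`, differs from compound 1 by methyl in place of hydrogen on a saturated chain carbon bound to a carbonyl carbon. Going by the values given here, no measured step touches a small lengthening of the acyl chain; the one step that was measured swaps an alkyl chain for an aromatic ring, which is a different kind of change. Compound 2, whose chain is longer still, sits at > 70000 nM. Compound 4 is therefore expected to give 100000 nM, with a range from 30000 nM to 300000 nM, which means an expected step that the limit leaves unreadable from compound 1 to compound 4, and most likely only another limit.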

Compound 4, concentration for 50% growth inhibition: 7720 nM
Compound 4: the middle estimate sits 13-fold (1.11 log units) above what was measured; the measured number lies below the stated range.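

The change from acetyl to propanoyl, one added methyl with no ring entering, gives an at least 9.0-fold lower number from compound 1 to compound 4 (0.95 log units; beyond the scatter) in this assay. For the compounds shown here, a swap to an aromatic ring is therefore not the only change here that moves a value off the limit, as an open-chain acyl group can also give a measured number, although compound 2, with its butanoyl group and a different amide substituent, goes against any simple rule. Compound 1 remains a limit and not a number, so the full size of this step stays unknown: the limit of > 70000 nM in this assay, at which 2 of the 4 values shown sit.

The compounds shown leave open whether lengthening the chain of compound 4 further, to pentanoyl or a longer chain, would lower the number again or return it to the limit. They also leave open how an amine or a carboxylic acid at the end of that chain would read.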